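Moving the thiazolyl attachment of compound 3

The source may hold more compounds than are shown below. What is called first, only, known or untested is meant among the compounds shown, and "the series" means these compounds.

In a functional assay on MCF7 cells (Homo sapiens) for antiproliferative activity, read by CellTiter-Glo, with a stated time of 5 days (a higher number here means a weaker inhibitor, a lower number a stronger inhibitor), compound 2 `CC/C(=C(/c1ccc(/C=C/C(=O)O)cc1)c1ccc2ccccc2c1)c1ccccc1` gives 180 nM and compound 3 `CC/C(=C(/c1ccc(/C=C/C(=O)O)cc1)c1ccc(-c2cscn2)cc1)c1ccccc1` gives 120 nM. These two values lie within the usual scatter of each other, so compound 3 cannot be separated from compound 2 on these numbers. Compound 1 `CC/C(=C(/c1ccc(/C=C/C(=O)O)cc1)c1ccc2ncsc2c1)c1ccccc1` is recorded in this assay as > 500 nM, which is a limit of the assay and not a number.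

The next structure is compound 4 `CC/C(=C(/c1ccc(/C=C/C(=O)O)cc1)c1ccc(-c2cncs2)cc1)c1ccccc1`. It has 1,3-thiazol-5-yl in place of 1,3-thiazol-4-yl on an aromatic carbon of a six-membered aromatic ring of carbon only, para to a large group: 1,3-thiazol-5-yl in place of 1,3-thiazol-4-yl on an aromatic carbon. The same atoms are simply joined differently.

Among the compounds with values here, only one measured step is available for comparison: an at least 2.7-fold lower number from compound 1 to compound 2 (0.44 log units; beyond the scatter). It lies beyond the scatter and shows that a change in this part of the molecule can move the number. However, it is a different exchange, and no measured pair tests a change of thiazolyl attachment. A shift beyond the scatter is therefore not expected in this assay, in either direction, though the uncertainty remains wide. The expected step is a 1.3-fold higher number from compound 3 to compound 4 (0.10 log units; within the scatter). For compound 4 the estimated value is 150 nM, with an expected range of 60 nM to 400 nM.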

Compound 4, half-maximal inhibitory concentration: 31 nM
The estimate for compound 4 lay 4.8-fold (0.68 log units) above the measured number; measured number outside the range, below it.
By their numbers in this assay, from the lowest: compound 4; then compounds 3 and 2 (each within the scatter of the next). At a limit, above all of these: compound 1.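

In this assay the exchange of 1,3-thiazol-4-yl for 1,3-thiazol-5-yl gives a 3.9-fold lower number from compound 3 to compound 4 (0.59 log units; beyond the scatter) and so shows that the point of attachment of the thiazole matters at this position on the six-membered aromatic ring of carbon only, para to a large group. The earlier compounds shown here could not show this: the step between compound 1 and compound 2 exchanges one ring system for another, whereas compound 3 and compound 4 have the same atoms and the same counts of hydrogen-bond donors and acceptors, joined differently. Nothing measured here accounts for the size of this step, so the numbers establish that the attachment point matters but not how it acts.

The remaining attachment, 1,3-thiazol-2-yl, does not appear among these compounds, so it remains open whether the number would fall further, return towards that of compound 3 or rise. As far as these compounds go, it is equally open whether the sulfur of the ring is needed, which a 1,3-oxazol-5-yl group in the same place would test, and whether a methyl group on the 1,3-thiazol-5-yl ring would be accepted.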